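A few compounds are considered here, and "the series" means these few. Any claim that something is new, unique, unknown or untested is made for them only; others in the source may bear on it.

Of the compounds shown here, three built on a shared core have been tested in a functional assay on isolated protein for agonist activity at Glucose-dependent insulinotropic receptor (Homo sapiens), read by HTRF and cAMP accumulation; a lower number here means that less compound is needed, a higher number that more compound is needed for the effect. Compound 1 `Cc1nc(O[C@H]2CC[C@H](OC3CCN(C(=O)OC(C)(C)C)CC3)CC2)ccc1C(=O)N(C)C` gives 262 nM, compound 2 `CC(C)(C)OC(=O)N1CCC(O[C@H]2CC[C@H](Oc3cnc(S(C)(=O)=O)cn3)CC2)CC1` gives 5.9 nM, and compound 3 `CS(=O)(=O)c1cnc(O[C@H]2CC[C@H](OC3CCN(C(=O)C4(C(F)(F)F)CCCC4)CC3)CC2)cn1` gives 38.4 nM, which places compound 3 second highest of the three numbers, between the other two. Among the compounds with values here, the only measured step that changes the group on the amine nitrogen in the ring is a 6.5-fold higher number from compound 2 to compound 3 (0.81 log units; beyond the scatter). Compound 4 `CC(C)c1noc(CN2CCC(O[C@H]3CC[C@H](Oc4cnc(S(C)(=O)=O)cn4)CC3)CC2)n1` differs from compound 3 in that same place: a group of 9 heavy atoms (6 carbon, 2 nitrogen, 1 oxygen; one five-membered aromatic ring with 3 hetero atoms) in place of a group of 11 heavy atoms (7 carbon, 1 oxygen, 3 fluorine; one five-membered non-aromatic ring of carbon only), on an amine nitrogen in a ring. Within the data shown here, no measured step swaps an aromatic group for a non-aromatic one there, so the expected step of a 1.3-fold lower number from compound 3 to compound 4 (0.11 log units; within the scatter) is small, and its direction is uncertain. Compound 4 is therefore estimated at 30 nM, with a range from 8 nM to 120 nM.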

Compound 4, half-maximal effective concentration: 14 nM
The estimate for compound 4 lay 2.1-fold (0.33 log units) above the measured number, within the range that was stated.
By their numbers in this assay, from the lowest: compound 2; then compound 4; then compound 3; then compound 1.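

The amine nitrogen in the ring need not carry a carbonyl-linked group: (3-isopropyl-1,2,4-oxadiazol-5-yl)methyl, the first group there with an aromatic ring, gives a 2.7-fold lower number from compound 3 to compound 4 (0.44 log units; beyond the scatter) and so improves on the trifluoromethyl cyclopentane group. It does not match tert-butoxycarbonyl, with a 2.4-fold higher number from compound 2 to compound 4 (0.38 log units; beyond the scatter) beyond the scatter, so tert-butoxycarbonyl keeps the lowest number of these three groups. Nothing measured here explains either step.

From the compounds shown here alone, it remains open whether the oxadiazole ring itself matters, as a plain benzyl group on that nitrogen would test. Also open, going by these compounds, is how a methyl or cyclopropyl group in place of the isopropyl would change the number.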